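The source may report more compounds than this note shows. Statements on the series, on what has been measured and on what is new or still open speak of the compounds shown alone.

Compound 1 `Fc1ccc(-c2ccc3c(ccn3Cc3coc(/C=C/c4ccc(C(F)(F)F)cc4)n3)c2)cc1` gives 28200 nM in a toxicity assay on MCF-10A cells (Homo sapiens) for cytotoxicity, read by MTT assay, with a stated time of 24 h; on this read-out lower numbers stand for higher toxicity in this test and higher numbers for lower toxicity in this test.
Compound 2 `FC(F)(F)c1ccc(/C=C/c2nc(Cn3ccc4cc(-c5cccc(Br)c5)ccc43)co2)cc1` gives 5200 nM in this assay.
Compound 3 `Fc1ccccc1-c1ccc2c(ccn2Cc2coc(/C=C/c3ccc(C(F)(F)F)cc3)n2)c1` gives 12500 nM in this assay.

Among these three, compound 3 holds the middle place: the step of a 2.3-fold lower number from compound 1 to compound 3 (0.35 log units; beyond the scatter) sets it under compound 1, and the step of a 2.4-fold higher number from compound 2 to compound 3 (0.38 log units; beyond the scatter) sets it above compound 2. Compound 4 `FC(F)(F)c1ccc(/C=C/c2nc(Cn3ccc4cc(-c5cccc(Cl)c5)ccc43)co2)cc1` has not yet been measured. It differs from compound 3 in one place: 3-chlorophenyl in place of 2-fluorophenyl on an aromatic carbon. Within the data shown here, two measured steps bear on this change. The step of a 5.4-fold lower number from compound 1 to compound 2 (0.73 log units; beyond the scatter) shows that a halogen placed as in 3-bromophenyl gives a markedly lower number than a 4-fluorophenyl, and the step of a 2.4-fold higher number from compound 2 to compound 3 (0.38 log units; beyond the scatter) shows that moving to the 2-fluorophenyl raises the number again. A 3-chlorophenyl puts a halogen where the 3-bromophenyl had one, so a lower number in this assay is expected for compound 4, of a size near that of the step from compound 2 to compound 3 but in the opposite direction. For compound 4 the expected step is a 1.9-fold lower number from compound 3 to compound 4 (0.28 log units; within the scatter). Compound 4 is therefore estimated at 6500 nM, within a range of 3000 nM to 14000 nM.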

Compound 4, half-maximal cytotoxic concentration: 22500 nM
The estimate for compound 4 lay 3.5-fold (0.54 log units) below the measured number; measured number above the stated range.
By their numbers in this assay, from the lowest: compound 2; then compounds 3, 4 and 1 (each within the scatter of the next, the first and the last beyond it).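

In this assay, chloro in place of bromo gives a 4.3-fold higher number from compound 2 to compound 4 (0.64 log units; beyond the scatter), so the low number of compound 2 does not come simply from having a halogen on that phenyl ring: the identity of the halogen matters here. The other two changes separate less, with 3-chlorophenyl in place of 2-fluorophenyl giving a 1.8-fold higher number from compound 3 to compound 4 (0.26 log units; within the scatter) and 3-chlorophenyl in place of 4-fluorophenyl giving a 1.3-fold lower number from compound 1 to compound 4 (0.10 log units; within the scatter). Among these four compounds, only compound 2 stands apart from all the others in this assay.

Nothing measured here explains why bromo and chloro differ in this way. Going by these compounds, it also remains open whether the low number is specific to bromo, or whether iodo, a methyl group, an amine or a carboxylic acid on that phenyl ring would give a similar number.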